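The source may report more compounds than this note shows. Statements on the series, on what has been measured and on what is new or still open speak of the compounds shown alone.

Measured so far:
- compound 1, `CCCCCCCCCCCCCCCCCC(=O)OCCCOP(=O)(O)OC[C@H](N)C(=O)O`: 40 nM
- compound 2, `CCCCCCCCCCCCCCCCCC(=O)CCCCOP(=O)(O)OC[C@H](N)C(=O)O`: "not determined" (no result reported)
- compound 3, `CCCCCCCCCCCCCCCCCC(=O)OC[C@H](COP(=O)(O)OC[C@H](N)C(=O)O)OC`: "not determined" (no result reported)

Of these, only compound 1 comes with a number. Among the compounds with values here, in a functional assay on cells (Mast cell, Mus musculus, strain C57BL/6) for activation, read by fluorescence, with a stated time of 15 min (on this read-out lower numbers stand for an effect already at smaller amounts and higher numbers for an effect only at larger amounts of compound), compound 1 gives 40 nM, the sole value available, so no comparison between measured compounds can be drawn and no step between them is known.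

Compound 4, `CCCCCCCCCCCCCCCCCC(=O)OC[C@H](O)COP(=O)(O)OC[C@H](N)C(=O)O`, has not been tested. It differs from compound 1 by a single change: hydroxy in place of hydrogen on a saturated chain carbon bound to two saturated chain carbons. Within the data shown here, with no measured step to lean on, the expectation is a small shift at most, none beyond the scatter of this assay in either direction.

Compound 4 is therefore expected to give about 30 nM, within a range of 10 nM to 120 nM, which corresponds to an estimated step of a 1.3-fold lower number from compound 1 to compound 4 (0.12 log units; within the scatter).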

Compound 4, half-maximal effective concentration: 70 nM
Estimate against measurement, compound 4: 2.3-fold (0.37 log units) below; the range from low to high includes it.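

In this assay, hydroxy in place of hydrogen on a saturated chain carbon bound to two saturated chain carbons gives a 1.8-fold higher number from compound 1 to compound 4 (0.24 log units; within the scatter) and stays within the scatter. This position therefore accepts a hydroxy, and compound 1 and compound 4 cannot be told apart on this read-out. Nothing available explains this result.

The steps to compound 2 and compound 3 cannot be read. On these data alone, whether this carbon would also accept an amine or a carboxylic acid remains open.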